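Chloro for methoxy on compound 3

The source may report more compounds than this note shows. Statements on the series, on what has been measured and on what is new or still open speak of the compounds shown alone.

Values so far in a functional assay on HT-29 cells (Homo sapiens) for antiproliferative activity, read by sulforhodamine B assay, with a stated time of 48 h (on this read-out higher numbers stand for weaker inhibition and lower numbers for stronger inhibition), as measured:
Compound 1 `COc1cccc(OS(=O)(=O)c2ccc(N3CCN(C)C3=O)cc2)c1` gives 2500 nM
Compound 2 `CN1CCN(c2ccc(S(=O)(=O)Oc3cccc(Cl)c3)cc2)C1=O` gives 2100 nM
Compound 3 `CCN1CCN(c2ccc(S(=O)(=O)Oc3cccc(OC)c3)cc2)C1=O` gives 22000 nM

In this assay compound 3 stands highest of the three with 22000 nM as its value. The change to compound 4 `CCN1CCN(c2ccc(S(=O)(=O)Oc3cccc(Cl)c3)cc2)C1=O` is chloro in place of methoxy on an aromatic carbon and it falls on an aromatic carbon, meta to a large group. Among the measured compounds shown here, the same exchange has been measured once, as a 1.2-fold lower number from compound 1 to compound 2 (0.08 log units; within the scatter) and this is the only direct guide. The other measured step, an 8.8-fold higher number from compound 1 to compound 3 (0.94 log units; beyond the scatter) lies at a different place and serves only to show that compound 3 starts from a different value. From the compounds shown here alone, whether the exchange carries over unchanged remains untested. Expected for the exchange here is a 1.2-fold lower number from compound 3 to compound 4 (0.09 log units; within the scatter) and thus no step beyond the scatter. Compound 4 is estimated at 18000 nM with 8000 nM to 40000 nM as the expected range.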

Compound 4, half-maximal inhibitory concentration: 6800 nM
Estimate against measurement, compound 4: 2.6-fold (0.42 log units) above; the whole stated range lies above it.
By their numbers in this assay, from the lowest: compounds 2 and 1 (each within the scatter of the next); then compound 4; then compound 3.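

In this assay, the exchange of 3-methoxyphenyl for 3-chlorophenyl is no longer silent, a 3.2-fold lower number from compound 3 to compound 4 (0.51 log units; beyond the scatter), so its size depends on the core: the same change on two cores in this assay, a 1.2-fold lower number (0.08 log units; within the scatter) from compound 1 to compound 2 and a 3.2-fold lower number (0.51 log units; beyond the scatter) from compound 3 to compound 4, 2.7-fold (0.43 log units) apart, beyond the scatter of two such steps

The added methyl likewise depends on the aromatic group, with a smaller step when chloro is present, a 3.2-fold higher number from compound 2 to compound 4 (0.51 log units; beyond the scatter), so the two changes do not add independently: the same change on two cores in this assay, an 8.8-fold higher number (0.94 log units; beyond the scatter) from compound 1 to compound 3 and a 3.2-fold higher number (0.51 log units; beyond the scatter) from compound 2 to compound 4, 2.7-fold (0.43 log units) apart, beyond the scatter of two such steps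

Open, from the compounds shown here alone, is whether this dependence persists with a longer chain on the amide-type nitrogen in the ring, or with an amine or a nitrile in place of chloro. These four compounds form a single pair of pairs and do not show why the steps differ.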